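Swapping the aryl group beside the carboxylic acid

The source may hold more compounds than are shown below. What is called first, only, known or untested is meant among the compounds shown, and "the series" means these compounds.

Measured compounds:
- compound 1 `Cc1nn(-c2nc(-c3ccc(Cl)c(Cl)c3)c(SC(C)C)s2)c(C(=O)O)c1Cc1ccccc1[N+](=O)[O-]`: 20000 nM
- compound 2 `Cc1nn(-c2nc(-c3ccc(Cl)c(Cl)c3)c(SC(C)C)s2)c(C(=O)O)c1-c1cccc(Cl)c1C`: 5100 nM
- compound 3 `Cc1nn(-c2nc(-c3ccc(Cl)c(Cl)c3)c(SC(C)C)s2)c(C(=O)O)c1-c1cnn(C)c1`: 6800 nM

These three compounds share a core and differ only in the group attached to the aromatic carbon next to the ring atom that bears a carboxy group. In a functional assay on BJAB cells (Homo sapiens) for antiproliferative activity, with a stated time of 4 days (a higher number here means that more compound is needed for the effect, a lower number that less compound is needed), compound 2 gives the lowest number of the three. The step of a 3.9-fold lower number from compound 1 to compound 2 (0.59 log units; beyond the scatter) is beyond the scatter, while the step of a 1.3-fold higher number from compound 2 to compound 3 (0.12 log units; within the scatter) is within it, so compound 2 and compound 3 cannot be told apart on this assay.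

Compound 4 `Cc1nn(-c2nc(-c3ccc(Cl)c(Cl)c3)c(SC(C)C)s2)c(C(=O)O)c1-c1cncc(C#N)c1` carries the change (5-cyanopyridin-3-yl in place of 3-chloro-2-methylphenyl on an aromatic carbon). The steps of a 3.9-fold lower number from compound 1 to compound 2 (0.59 log units; beyond the scatter) and a 2.9-fold lower number from compound 1 to compound 3 (0.47 log units; beyond the scatter) show that two quite different aromatic groups at this carbon both give a modest improvement over the 2-nitrobenzyl compound, and the step of a 1.3-fold higher number from compound 2 to compound 3 (0.12 log units; within the scatter) shows that a six-membered carbon ring and a small heteroaromatic ring land close together. A six-membered ring with a nitrogen and a nitrile is expected to behave like these two, so the expected step of a 1.2-fold higher number from compound 2 to compound 4 (0.07 log units; within the scatter) is none beyond the scatter. Compound 4 is therefore estimated at 6000 nM, with a range from 2500 nM to 15000 nM in this assay.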

Compound 4, half-maximal effective concentration: 20000 nM
For compound 4 the middle estimate is 3.3-fold (0.52 log units) below the measured one, outside the stated range (above it).
By their numbers in this assay, from the lowest: compounds 2 and 3 (each within the scatter of the next); then compounds 1 and 4 (each within the scatter of the next).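

In this assay, an aromatic ring on this carbon does not always fall in the same range: there is a 3.9-fold higher number from compound 2 to compound 4 (0.59 log units; beyond the scatter), and there is a 2.9-fold higher number from compound 3 to compound 4 (0.47 log units; beyond the scatter). With no change at the digits printed from compound 1 to compound 4 (within the scatter), the result also shows that a ring bonded directly to this carbon does not by itself give the lower numbers. The 3-chloro-2-methylphenyl and 5-cyanopyridin-3-yl groups have the same heavy-atom count, so that count does not separate these results.

No measurement here explains the rise. A plain pyridin-3-yl group and a 3-cyanophenyl group would help separate the contribution of the ring nitrogen from that of the nitrile, leaving open which of the two goes with the higher number.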